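The compounds below may be only part of what the source reports. "The series", "measured", "known", "first", "only" and "open" are said of these compounds alone.

Working notes on the series. The shared core of compound 1 `C[C@H]1[C@H](NCc2cncs2)C[C@H]2C[C@@H]1C2(C)C` carries an amine nitrogen bearing a substituted methylene; the aromatic group on that carbon varies across the set. In an ADME assay on MDCK cells (Canis lupus familiaris) for cytotoxicity, read by microscopy, with a stated time of 48 h (a higher number here means that more compound is tolerated, a lower number that less compound is tolerated), compound 1 gives > 100000 nM, which is a limit of the assay and not a number. Compound 1 therefore sits at the limit of > 100000 nM in this assay, at which 1 of the 3 values shown sits, the highest point reported for the set. Compound 2 `C=C(C)c1csc(CN[C@@H]2C[C@H]3C[C@@H]([C@H]2C)C3(C)C)c1` gives 25000 nM in this assay. Compound 3 `C[C@H]1[C@H](NCc2sccc2-c2ccccc2)C[C@H]2C[C@@H]1C2(C)C` gives 12500 nM in this assay. Compound 4 `Cc1n[nH]cc1CN[C@@H]1C[C@H]2C[C@@H]([C@H]1C)C2(C)C` has not been measured in this assay; it differs from compound 1 in one place (3-methyl-1H-pyrazol-4-yl in place of 1,3-thiazol-5-yl on a saturated chain carbon bound to an amine nitrogen). For the measured compounds named here, no measured step between two compounds differing in a single place is available, so the step from compound 1 to compound 4 cannot be anchored to a precedent. The expectation is of no change beyond the scatter in this assay, an at least 1.2-fold lower number from compound 1 to compound 4 (0.09 log units; that floor lies within the scatter), with a fair chance that only a limit is again reported. Compound 4 is expected at 80000 nM, within a range of 25000 nM to 200000 nM.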

Compound 4, minimum cytotoxic concentration: > 100000 nM
Compound 4: no number, only a limit; the forecaster's own chance of this, stated with the estimate: 55%; at least 1.2-fold (0.09 log units) between middle value and limit.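

In this assay compound 4 gives > 100000 nM, a limit of the assay and not a number. For the compounds shown here, compound 1 also stands at a limit, so no step between compound 1 and compound 4 can be read. Left open is whether 3-methyl-1H-pyrazol-4-yl in place of 1,3-thiazol-5-yl changes the result in this assay at all.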